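The compounds below may be only part of what the source reports. "The series", "measured", "known", "first", "only" and "open" are said of these compounds alone.

Measured in a functional assay on HL-60 cells (Homo sapiens) for antiproliferative activity; on this read-out higher numbers stand for weaker inhibition and lower numbers for stronger inhibition:
- compound 1 `COc1c(C)c2c(c(O)c1C/C=C(\C)CCC(=O)OC[C@@H]1O[C@H](n3cnc4c(N)ncnc43)[C@@H](O)[C@H]1O)C(=O)OC2`: 2100 nM
- compound 2 `COc1c(C)c2c(c(O)c1C/C=C(\C)CCC(=O)NC[C@H]1O[C@@H](n3cnc4c(N)ncnc43)[C@H](O)[C@@H]1O)C(=O)OC2`: > 100000 nM

Going by the values given here, compound 1, at 2100 nM, carries the only actual number in this assay. Compound 2 reads > 100000 nM, which is a limit of the assay and not a number. Compound 3 `COc1c(C)c2c(c(O)c1C/C=C(\C)CCC(=O)OC[C@H]1O[C@@H](n3cnc4c(N)ncnc43)[C@H](O)[C@@H]1O)C(=O)OC2` has the same atoms and bonds as compound 1 and differs only in configuration as drawn: the two compounds have the same atoms and bonds and differ only in configuration as drawn: 4 of 5 stereo elements differ; a stereocentre at a saturated ring carbon is drawn S in compound 1 and R in compound 3; a stereocentre at a saturated ring carbon is drawn S in compound 1 and R in compound 3; a stereocentre at a saturated ring carbon is drawn S in compound 1 and R in compound 3; a stereocentre at a saturated ring carbon is drawn R in compound 1 and S in compound 3. Among the compounds with values here, no measured step bears on this change, so the expectation is only a small move toward stronger inhibition, near the scatter. The expected change is a 2.1-fold lower number from compound 1 to compound 3 (0.32 log units; beyond the scatter). For compound 3 the estimated value is 1000 nM, with an expected range of 200 nM to 6000 nM.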

Compound 3, half-maximal inhibitory concentration: 9300 nM
Compound 3: middle estimate off by 9.3-fold (0.97 log units), on the low side; the measured number lies above the stated range.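

In this assay, going by these compounds alone, inverting four of the five drawn stereo elements while keeping every atom and bond gives a 4.4-fold higher number from compound 1 to compound 3 (0.65 log units; beyond the scatter), the first readable step. The shift can therefore be set on the configuration as drawn alone: the fact that compounds 1 and 3 differ only in the configuration as drawn. Within the data shown here, compound 2 reads > 100000 nM, which is a limit of the assay and not a number, so no step to it can be read.

As far as these compounds go, all four stereocentres change together, and which of them carries the shift stays open. Also open, from the compounds shown here alone, is how a longer chain in place of the ester link would read at either configuration.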